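Swapping the aryl group on the piperazine nitrogen

The source may report more compounds than this note shows. Statements on the series, on what has been measured and on what is new or still open speak of the compounds shown alone.

Compound 1 `Nc1scc(CN2CCN(c3ccc(Cl)cc3F)CC2)c1C(=O)c1ccc(Cl)cc1`: -57%
Compound 2 `COc1ccc(N2CCN(Cc3csc(N)c3C(=O)c3ccc(Cl)cc3)CC2)cc1`: -15%
Compound 3 `Nc1scc(CN2CCN(c3ccccc3C(F)(F)F)CC2)c1C(=O)c1ccc(Cl)cc1`: -39%

In a functional assay on CHO cells with adenosine receptor A1 (Homo sapiens) as the target, read by cAMP accumulation and immunoassay, with a stated time of 6 min, tested at 1 uM (on this read-out higher numbers stand for a weaker effect at the one concentration tested and lower numbers for a stronger effect), compound 3 gives the second highest of the three numbers, sitting between compound 1 and compound 2. Compound 4 `Nc1scc(CN2CCN(c3cc(F)ccc3F)CC2)c1C(=O)c1ccc(Cl)cc1` differs from compound 3 in one place: 2,5-difluorophenyl in place of 2-(trifluoromethyl)phenyl on an amine nitrogen in a ring. Among the compounds with values here, two measured steps touch the same position. The step of a number 18 percentage points higher from compound 1 to compound 3 (beyond the scatter) shows that a halogenated aryl gave a stronger effect than the trifluoromethyl aryl, while a number 24 percentage points lower from compound 2 to compound 3 (beyond the scatter) shows the methoxy aryl gave a weaker one. Since compound 4 carries a halogenated aryl like compound 1, a modest move downward is expected, a number 6 percentage points lower from compound 3 to compound 4 (within the scatter), though it may stay within the scatter. Compound 4 is therefore estimated at -45%, within -65% to -25%.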

Compound 4, a percentage reported as activity, at one concentration (the size of the read-out at that concentration, not a potency): -59%
Beside the measured number, compound 4's estimate is 14 percentage points above it; the measured number falls inside the stated range.
By their numbers in this assay, from the lowest: compounds 4 and 1 (each within the scatter of the next); then compound 3; then compound 2.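

In this assay, 2,5-difluorophenyl gives a clearly stronger effect than 2-(trifluoromethyl)phenyl (a number 20 percentage points lower from compound 3 to compound 4 (beyond the scatter)) and much stronger than 4-methoxyphenyl (a number 44 percentage points lower from compound 2 to compound 4 (beyond the scatter)). It cannot be told apart from 4-chloro-2-fluorophenyl (a number 2 percentage points lower from compound 1 to compound 4 (within the scatter)), so among these compounds a chlorine on this phenyl is not needed for an effect of this size. No measurement shown explains these steps. Still open, from the compounds shown here alone, is how an unsubstituted phenyl or a pyridyl group on the same ring nitrogen would compare with these aryl groups.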